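This account rests on a few compounds, and the source may have more. Where it says the series, first, only, none or still open, it means among the compounds named here.

Of the compounds shown here, two built on the same core have been measured in a functional assay on MCF7 cells (Homo sapiens) for antiproliferative activity, read by MTT assay, with a stated time of 72 h; on this read-out higher numbers stand for weaker inhibition and lower numbers for stronger inhibition. Compound 1 `CCOC(=O)c1oc2ccc(NS(=O)(=O)c3ccccc3C(F)(F)F)cc2c1C` gives 93900 nM in this assay. Compound 2 `CCOC(=O)c1oc2ccc(NS(=O)(=O)c3cccc([N+](=O)[O-])c3)cc2c1C` gives 74800 nM in this assay. The two numbers lie within the usual scatter of each other, so neither compound 1 nor compound 2 can be called the more active one; both inhibit growth only weakly.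

Compound 3 `CCOC(=O)c1oc2ccc(NS(=O)(=O)c3ccccc3[N+](=O)[O-])cc2c1C` has not yet been measured. It differs from compound 2 in one place: 2-nitrophenyl in place of 3-nitrophenyl on a sulfonyl sulfur. Within the data shown here, no measured pair shows what moving a group around this ring does, but compound 1 and compound 2, which carry different groups on the same ring, give numbers in this assay that are within the scatter of each other, so no step beyond the scatter is expected here either. The step from compound 2 to compound 3 is estimated as a 1.1-fold higher number from compound 2 to compound 3 (0.03 log units; within the scatter). Compound 3 is thus expected to give about 80000 nM in this assay, plausibly anywhere from 35000 nM to 180000 nM.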

Compound 3, half-maximal inhibitory concentration: 157000 nM
Estimate against measurement, compound 3: 2.0-fold (0.29 log units) below; measured number inside the range.
By their numbers in this assay, from the lowest: compounds 2, 1 and 3 (each within the scatter of the next, the first and the last beyond it).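

In this assay, among these compounds, moving the nitro group around the ring on the sulfonyl sulfur, with 2-nitrophenyl in place of 3-nitrophenyl, gives a 2.1-fold higher number from compound 2 to compound 3 (0.32 log units; beyond the scatter) and is the first measured change on this ring to pass the scatter, though only modestly. Nitro in place of trifluoromethyl on an aromatic carbon gives a 1.7-fold higher number from compound 1 to compound 3 (0.22 log units; within the scatter) so, in this pair, the exchange of one group for the other cannot be told apart from repeat-to-repeat variation. Nothing measured here explains why the placement of the nitro group should affect the number. The compounds shown leave open whether an amine or a carboxylic acid on this ring would shift the number further. They also leave open whether a carboxylic acid in place of the ethyl ester on the shared core would give stronger inhibition.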